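Urea in Place of Amide on the Shared Core

The source may report more compounds than this note shows. Statements on the series, on what has been measured and on what is new or still open speak of the compounds shown alone.

Of the compounds shown here, three on the shared core have been measured in a functional assay on SNB-19 cells (Homo sapiens) for inhibition, read by sulforhodamine B assay, with a stated time of 48 h, tested at 10 uM; on this read-out higher numbers stand for a weaker effect at the one concentration tested and lower numbers for a stronger effect. Compound 1 `COc1cc(Cl)cc(-c2nn(-c3cccc(NC(=O)Nc4cccc(C(F)(F)F)c4)c3)cc2-c2ccncc2)c1` gives 16.1%, compound 2 `COc1cc(Cl)cc(-c2nn(-c3cccc(NC(=O)c4cc(C(F)(F)F)cc(C(F)(F)F)c4)c3)cc2-c2ccncc2)c1` gives 86.4%, and compound 3 `COc1cc(Cl)cc(-c2nn(-c3cccc(NC(=O)c4cccc(C(F)(F)F)c4)c3)cc2-c2ccncc2)c1` gives 82.2%. Compound 3 stands second highest of the three numbers; its nearest neighbour is compound 2, with the step of a number 4.2 percentage points lower from compound 2 to compound 3 (within the scatter) lying within the scatter, while the step of a number 66.1 percentage points higher from compound 1 to compound 3 (beyond the scatter) is large and beyond the scatter.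

Compound 4 `COc1cc(Cl)cc(-c2nn(-c3cccc(NC(=O)Nc4ccc(Cl)c(Cl)c4)c3)cc2-c2ccncc2)c1` differs from compound 3 in one place: (3,4-dichlorophenyl)amino in place of 3-(trifluoromethyl)phenyl on a carbonyl carbon. Within the data shown here, of the measured steps only the one from compound 1 to compound 3 bears on this change, as it too exchanges an arylamino group for an aryl group on the carbonyl carbon, although the aryl part differs as well. Among the measured compounds shown here, no measured pair separates 3-(trifluoromethyl)phenyl from 3,4-dichlorophenyl on this position, so that part of the change is unresolved. A large downward step is therefore expected in this assay, roughly reversing the earlier one, a number 60.2 percentage points lower from compound 3 to compound 4 (beyond the scatter). For compound 4 an activity of 22% is estimated, in the range 8% to 48%.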

Compound 4, a percentage reported as activity, at one concentration (the size of the read-out at that concentration, not a potency): 17.8%
The estimate for compound 4 lay 4.2 percentage points above the measured number, within the range that was stated.
By their numbers in this assay, from the lowest: compounds 1 and 4 (each within the scatter of the next); then compounds 3 and 2 (each within the scatter of the next).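

With a second aryl group on the urea, the gain from urea in place of amide no longer rests on compound 1 alone: in this assay the step is a number 64.4 percentage points lower from compound 3 to compound 4 (beyond the scatter), which shows a large effect of the change on this carbonyl carbon in a second pair. The aryl part left unresolved earlier can now be read directly, as the step is a number 1.7 percentage points higher from compound 1 to compound 4 (within the scatter), so 3,4-dichlorophenyl and 3-(trifluoromethyl)phenyl cannot be told apart on the urea in this read-out. Nothing at hand explains the difference between urea and amide.

On these data alone, it remains open whether the urea hydrogen itself matters, which a methyl group on that nitrogen or a carbamate oxygen in its place would test. Also open, as far as these compounds go, is whether the urea requires an aromatic ring at all, which a cyclohexyl group would address.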